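A Phenethyl Amide Replaces Isobutyl on the Shared Core

This account rests on a few compounds, and the source may have more. Where it says the series, first, only, none or still open, it means among the compounds named here.

Compound 3 `CCCSc1nc(Cl)c2c(n1)N(Cc1ccccc1)C(C(=O)NCC(C)C)N2` carries an isobutylamino group on its carbonyl carbon. Among the measured compounds shown here, in a functional assay on TE-1 cells (Homo sapiens) for antiproliferative activity, read by MTT assay, with a stated time of 72 h (on this read-out higher numbers stand for weaker inhibition and lower numbers for stronger inhibition), compound 3 gives 46600 nM, the highest of the two numbers known, with compound 2 the nearest. Compound 2 `CCCSc1nc(Cl)c2c(n1)N(Cc1ccccc1)C(C(=O)NCCC1=CCc3ccccc31)N2` gives 30000 nM in this assay. Compound 1 `CCCSc1nc(Cl)c2c(n1)N(Cc1ccccc1)C(C(=O)O)N2` reaches only a limit in this assay, > 64000 nM. This is the limit of > 64000 nM in this assay, at which 1 of the 3 values shown sits. Two measured steps are known: an at least 1.3-fold lower number from compound 1 to compound 3 (0.13 log units; that floor lies within the scatter), and a 1.6-fold higher number from compound 2 to compound 3 (0.19 log units; within the scatter).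

Compound 4 `CCCSc1nc(Cl)c2c(n1)N(Cc1ccccc1)C(C(=O)NCCCc1ccccc1)N2` differs from compound 3 in one place: phenethyl in place of isopropyl on a saturated chain carbon bound to an amide-type nitrogen. For the measured compounds named here, the step that bears on this change is the one from compound 2 to compound 3, where a larger chain with two rings gave way to a short chain and the number stayed within the scatter. Reversing that direction, toward a chain with one ring, is therefore expected to change the number little, perhaps a small decrease that itself lies within the scatter. Compound 4 is expected to give 35000 nM in this assay, with a range from 15000 nM to 70000 nM. The expected step is a 1.3-fold lower number from compound 3 to compound 4 (0.12 log units; within the scatter).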

Compound 4, half-maximal inhibitory concentration: 23000 nM
Compound 4: the middle estimate sits 1.5-fold (0.18 log units) above what was measured, and the stated range covers the measured number.
By their numbers in this assay, from the lowest: compounds 4, 2 and 3 (each within the scatter of the next, the first and the last beyond it). At a limit, above all of these: compound 1.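

In this assay, phenethyl in place of isopropyl on a saturated chain carbon bound to an amide-type nitrogen gives a 2.0-fold lower number from compound 3 to compound 4 (0.31 log units; beyond the scatter), the first step among these amides that lies beyond the scatter, though only modestly. The chain of compound 4 and the two-ring chain of compound 2 cannot be told apart, with a 1.3-fold lower number from compound 2 to compound 4 (0.12 log units; within the scatter). (3-Phenylpropyl)amino in place of hydroxy on the carbonyl carbon gives an at least 2.7-fold lower number from compound 1 to compound 4 (0.44 log units; beyond the scatter), which is only a floor, as compound 1 stands at a limit of the assay: the limit of > 64000 nM in this assay, at which 1 of the 4 values shown sits.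

The compounds shown leave open whether the benzene ring or simply the longer chain goes with the lower number, a question that an unbranched butyl or hexyl amide could address. Also open, going by these compounds, is whether an amine or a carboxylic acid at the end of the 3-phenylpropyl chain would shift the number.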